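Swapping bromo for methyl in a cytotoxicity series

A few compounds are considered here, and "the series" means these few. Any claim that something is new, unique, unknown or untested is made for them only; others in the source may bear on it.

Measured in a toxicity assay on J774.A1 cells (Mus musculus) for cytotoxicity, read by SYBR Green assay, with a stated time of 1 h; on this read-out higher numbers stand for an effect only at larger amounts of compound and lower numbers for an effect already at smaller amounts:
Compound 1 `CN(C)c1ccc2cc(-c3ccccc3)c(N)nc2c1`: 4900 nM
Compound 2 `CN(C)c1ccc2cc(-c3ccccc3Br)c(N)nc2c1`: 12000 nM

For the measured compounds named here, compound 2 has the higher of the two numbers measured so far, which means it needs the larger amount to show an effect in this assay. The next compound, compound 3 `Cc1ccccc1-c1cc2ccc(N(C)C)cc2nc1N`, keeps the shared core and changes one group: methyl in place of bromo on an aromatic carbon. Put simply, this is methyl in place of bromo on an aromatic carbon, turning 2-bromophenyl into 2-methylphenyl.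

Going by the values given here, only one measured step bears on this change. Bromo in place of hydrogen on an aromatic carbon gave a 2.4-fold higher number from compound 1 to compound 2 (0.39 log units; beyond the scatter), a modest change. Among the compounds with values here, no measured compound carries the methyl, so its effect on the number is unknown. Since that single step was modest, only a small shift is likely when the bromo leaves. The expected step is a 1.5-fold lower number from compound 2 to compound 3 (0.18 log units; within the scatter), so none beyond the usual scatter is foreseen, with the estimate leaning towards a lower number. For compound 3 the estimate is 8000 nM, with an expected range of 3500 nM to 16000 nM.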

Compound 3, half-maximal effective concentration: 6800 nM
For compound 3 the middle estimate is 1.2-fold (0.07 log units) above the measured one; low and high end bracket the measured number.
By their numbers in this assay, from the lowest: compounds 1, 3 and 2 (each within the scatter of the next, the first and the last beyond it).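

In this assay the swap gives a 1.8-fold lower number from compound 2 to compound 3 (0.25 log units; within the scatter), so at this place, on an aromatic carbon ortho to a large group, the measured numbers do not tell methyl apart from bromo. Compared with hydrogen at the same place, methyl gives a 1.4-fold higher number from compound 1 to compound 3 (0.14 log units; within the scatter), so the numbers do not tell it apart from hydrogen either, even though the step from hydrogen to bromo lies beyond the scatter. Methyl therefore sits within the scatter of both neighbouring compounds, and no measurement at hand offers a reason for these small steps.

The compounds shown carry only hydrogen, bromo or methyl at this place, so it remains open whether an amine, a carboxylic acid or a longer chain there would move the number beyond the scatter. Going by these compounds, it also remains open whether the swap from bromo to methyl would give a similarly small step at another place on this aromatic ring.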